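The source may report more compounds than this note shows. Statements on the series, on what has been measured and on what is new or still open speak of the compounds shown alone.

Three compounds that share one core and differ only in the amino group on a saturated chain carbon were tested in a functional assay on MCF7 cells (Homo sapiens) for antiproliferative activity; on this read-out lower numbers stand for stronger inhibition and higher numbers for weaker inhibition. There compound 1 (`CC(C)=CCc1cc(C(=O)Nc2cc3ccc(OCCCN4CCCC4)c(C)c3oc2=O)ccc1O`) gives 990 nM, compound 2 (`CC(C)=CCc1cc(C(=O)Nc2cc3ccc(OCCCN(C)C(C)C)c(C)c3oc2=O)ccc1O`) gives 1050 nM and compound 3 (`CC(C)=CCc1cc(C(=O)Nc2cc3ccc(OCCCNCC(N)=O)c(C)c3oc2=O)ccc1O`) gives 1460 nM. Compound 3 therefore stands within the scatter of both others. Compound 4 (`CC(C)=CCc1cc(C(=O)Nc2cc3ccc(OCCCNC(C)(C)c4ccccc4)c(C)c3oc2=O)ccc1O`) has 1-methyl-1-phenylethyl in place of carbamoylmethyl on an amine nitrogen. Among the measured compounds shown here, three measured steps bear on this change, since all of them alter the same amino group: a 1.1-fold higher number from compound 1 to compound 2 (0.03 log units; within the scatter), a 1.5-fold higher number from compound 1 to compound 3 (0.17 log units; within the scatter) and a 1.4-fold higher number from compound 2 to compound 3 (0.14 log units; within the scatter). Each lies within the scatter. For the measured compounds named here, none of the measured compounds carries an aromatic ring on that amine nitrogen, so the data reach the entering group only indirectly. No step beyond the scatter is expected in this assay, and the estimated step is a 1.5-fold lower number from compound 3 to compound 4 (0.16 log units; within the scatter). The estimate for compound 4 is 1000 nM, with an expected range from 400 nM to 2500 nM.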

Compound 4, half-maximal inhibitory concentration: 1070 nM
Estimate against measurement, compound 4: 1.1-fold (0.03 log units) below, within the range that was stated.
By their numbers in this assay, from the lowest: compounds 1, 2, 4 and 3 (each within the scatter of the next).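

In this assay, 1-methyl-1-phenylethyl on the amine nitrogen proved no different from carbamoylmethyl (a 1.4-fold lower number from compound 3 to compound 4 (0.13 log units; within the scatter)), and the (1-methyl-1-phenylethyl)amino group matched both isopropyl(methyl)amino (a 1.0-fold higher number from compound 2 to compound 4 (0.01 log units; within the scatter)) and pyrrolidin-1-yl (a 1.1-fold higher number from compound 1 to compound 4 (0.03 log units; within the scatter)). The earlier compounds shown here carried no aromatic ring on this nitrogen, so compound 4 extends the flat response at this position to a group with a six-membered aromatic ring and no hydrogen-bond donor or acceptor of its own. No available evidence accounts for this lack of response.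

Going by these compounds, whether a benzyl group or a carboxylic acid on that amine nitrogen, or a longer chain leading to it, would move the number beyond the scatter remains open. The compounds also leave open how changes elsewhere on the shared core would read.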